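Swapping chloro for methyl on a benzothiazole urea

A few compounds are considered here, and "the series" means these few. Any claim that something is new, unique, unknown or untested is made for them only; others in the source may bear on it.

Compound 1, `O=C(Nc1cccc([N+](=O)[O-])c1)Nc1nc2ccc(Cl)cc2s1`, gives 2.21 ug/mL in a functional assay on SK-HEP1 cells (Homo sapiens) for antiproliferative activity, read by sulforhodamine B assay; a lower number here means a stronger inhibitor of growth, a higher number a weaker inhibitor of growth.
Compound 2, `O=C(Nc1nc2ccc([N+](=O)[O-])cc2s1)c1ccc(C(F)(F)F)cc1`, gives 2.1 ug/mL in this assay.
Compound 3, `COc1ccc(C(=O)Nc2nc3cc(C)cc(C)c3s2)cc1`, gives only a limit in this assay, > 10 ug/mL.

Among the three measured compounds, compound 1 holds the highest of the two actual numbers, and its nearest neighbour, compound 2, sits within the usual scatter of it, so the two cannot be told apart. Compound 3 stands apart as a limit value (the limit of > 10 ug/mL in this assay, at which 1 of the 3 values shown sits), which is not a number.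

Compound 4, `Cc1ccc2nc(NC(=O)Nc3cccc([N+](=O)[O-])c3)sc2c1`, is the compound still to be measured. It differs from compound 1 in a single spot: methyl in place of chloro on an aromatic carbon. The urea linker and the nitrophenyl group are kept unchanged.

Going by the values given here, no measured pair shows what this exchange does to growth inhibition, so the direction has to be guessed. The chloro and the methyl group are of similar size, and the rest of the molecule is untouched. The expectation is therefore a step of modest size at most, with a weak lean towards a somewhat higher number, as in a 1.6-fold higher number from compound 1 to compound 4 (0.20 log units; within the scatter). Compound 4 is estimated at 3.5 ug/mL in this assay, with a plausible range from 1.5 ug/mL to 10 ug/mL.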

Compound 4, concentration for 50% growth inhibition: > 10 ug/mL
Compound 4 gave a limit, no number; the forecaster's own chance of this, stated with the estimate: 25%; at least 2.8-fold (0.45 log units) between middle value and limit.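

Going by these compounds alone, until now, no pair of compounds showed what a change on this aromatic carbon does; in this assay, methyl in place of chloro gives an at least 4.5-fold higher number from compound 1 to compound 4 (0.65 log units; beyond the scatter). Within this pair, growth inhibition therefore depends on which of the two groups sits at this place, even though the urea linker and the nitrophenyl group stay the same. The result for compound 4 is a limit and not a number, and it is one of two such results: the limit of > 10 ug/mL in this assay, at which 2 of the 4 values shown sit.

A single pair cannot tell whether chloro is specially suited to this carbon or whether methyl is simply poorly tolerated there, and other groups at the same place, such as bromo or an amine, would be needed to separate those two readings. From the compounds shown here alone, it also remains open whether the same exchange would matter as much in compounds with another linker or with something other than the nitrophenyl group, so the finding holds for this one pair only.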